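A few compounds are considered here, and "the series" means these few. Any claim that something is new, unique, unknown or untested is made for them only; others in the source may bear on it.

Measured so far in a physicochemical assay for lipophilicity, using the shake flask method, measured as octanol-water partition, at 23 degrees C; a higher number here means a more lipophilic compound, a lower number a more polar compound:
compound 1 `CS/C(=N\C#N)N(C)Cc1ccc(Cl)nc1` gives 1.4;
compound 2 `CCN/C(=N\C#N)NCc1ccc(Cl)nc1` gives 0.86;
compound 3 `CN(Cc1ccc(Cl)nc1)/C(N)=N/C#N` gives 0.71.

Compound 3 and compound 2 lie within the scatter of each other, while compound 1 stands apart: the step of a number 0.69 log units lower from compound 1 to compound 3 (beyond the scatter) is the only single-change step among these three. Compound 4 `CN(Cc1ccc(Cl)nc1)/C(=N/C#N)NCc1ccccc1` comes from compound 3 by benzyl in place of hydrogen on an amine nitrogen. Going by the values given here, no measured pair shows this change; the one known step concerns a different group on a different position, so it does not speak to the new step directly. Even so, the benzyl entering where a hydrogen stood is expected to raise this assay well beyond the scatter. Compound 4 is therefore estimated at 2.4, between 1.8 and 3. The expected step is a number 1.69 log units higher from compound 3 to compound 4 (beyond the scatter).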

Compound 4, partition coefficient: 1.32
Compound 4: the middle estimate sits 1.08 log units above what was measured, and the stated range ends above it.
By their numbers in this assay, from the lowest: compounds 3 and 2 (each within the scatter of the next); then compounds 4 and 1 (each within the scatter of the next).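

In this assay, going by these compounds alone, benzyl in place of hydrogen on this amine nitrogen gives a number 0.61 log units higher from compound 3 to compound 4 (beyond the scatter) and so offers the first reading of a change at this position. The step is modest for a group of 7 heavy atoms, all carbon and forming one six-membered aromatic ring. Nothing measured here explains its size. Still open, on these data alone, is whether the aromatic ring or the carbon count matters more. Cyclohexylmethyl or a longer chain such as phenylethyl on the same amine nitrogen could separate the two.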